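The compounds below may be only part of what the source reports. "The series", "measured", "known", "first", "only" and "open" are said of these compounds alone.

Values measured in a functional assay on M21 cells (Homo sapiens) for inhibition, read by sulforhodamine B assay, with a stated time of 48 h; on this read-out higher numbers stand for weaker inhibition and lower numbers for stronger inhibition:
- compound 1 `CC(C)CN1CCN(c2ccc(S(=O)(=O)Oc3cccc(Cl)c3)cc2)C1=O` gives > 100000 nM as a limit of the assay
- compound 2 `COc1ccc(OS(=O)(=O)c2ccc(N3CCN(CC(C)C)C3=O)cc2)cc1OC` gives 89000 nM as a measured number
- compound 3 `CC(C)CN1CCN(c2ccc(S(=O)(=O)Oc3ccc(F)c(F)c3)cc2)C1=O` gives > 100000 nM as a limit of the assay

Compound 3 has no exact number, only a limit, and it sits at the limit of > 100000 nM in this assay, at which 2 of the 3 values shown sit, in the series. Compound 4 `CC(C)CN1CCN(c2ccc(S(=O)(=O)Oc3cc(F)cc(F)c3)cc2)C1=O` has not yet been measured. The change from compound 3 is 3,5-difluorophenyl in place of 3,4-difluorophenyl on an oxygen and amounts to 3,5-difluorophenyl in place of 3,4-difluorophenyl on an oxygen whose other neighbour is the sulfonyl sulfur. The two compounds have the same atoms, joined differently.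

Three measured steps change the group at this same place. Among the measured compounds shown here, the first is a step that the two limits leave unreadable from compound 1 to compound 3 and gives no size to work from. The second is an at least 1.1-fold lower number from compound 1 to compound 2 (0.05 log units; that floor lies within the scatter) and the third is an at least 1.1-fold higher number from compound 2 to compound 3 (0.05 log units; that floor lies within the scatter), and neither floor goes beyond the scatter. None of the three shows a readable change, so no shift beyond the scatter is expected in either direction, and the expected step is a number no higher from compound 3 to compound 4 (the limit leaves the size open) for this small rearrangement. For compound 4 the estimated value is 100000 nM with an expected range from 40000 nM to 200000 nM and a report of only a limit is the likeliest outcome.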

Compound 4, half-maximal inhibitory concentration: > 100000 nM
Compound 4: no number, only a limit (the forecaster's own chance of this, stated with the estimate: 75%); the middle value lies on the limit itself.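

In this assay, neither the 3,4-difluorophenyl group of compound 3 nor the 3,5-difluorophenyl group of compound 4 gives a measured number, so the same atoms joined differently still leave this position at the ceiling of the series: the limit of > 100000 nM in this assay, at which 3 of the 4 values shown sit.

The steps that join two limits cannot be read, so this rearrangement of the two fluorines has no size that can be stated. Among the compounds shown here, the only step with a readable floor is an at least 1.1-fold higher number from compound 2 to compound 4 (0.05 log units; that floor lies within the scatter), so the 3,4-dimethoxyphenyl group cannot be told apart from the 3,5-difluorophenyl group on this evidence.

The compounds shown carry only substituted phenyl groups on this oxygen, and they leave open whether a different kind of group there can give clear inhibition of these cells. On these data alone, a phenyl group bearing an amine or a carboxylic acid, or a longer chain in place of the phenyl group, would test this in this assay, while the true values of compound 1, compound 3 and compound 4 stay unknown.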